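The source may report more compounds than this note shows. Statements on the series, on what has been measured and on what is new or still open speak of the compounds shown alone.

Measured compounds:
- compound 1, `Fc1cccc(-c2cn([C@@H]3CN4CCC3CC4)nn2)c1`: 519 nM
- compound 2, `Fc1ccc(-c2cn(C3CN4CCC3CC4)nn2)cc1`: 449 nM
- compound 3, `Fc1cccc(-c2cn(C3CN4CCC3CC4)nn2)c1`: 748 nM

All three were run in an assay on HEK293 cells for displacement of a labelled ligand from Neuronal acetylcholine receptor; alpha4/beta2 (Homo sapiens), read by scintillation counting, with a stated time of 120 min; a lower number here means a stronger inhibitor, a higher number a weaker inhibitor. Compound 3 holds the highest of the three numbers, but the step of a 1.4-fold higher number from compound 1 to compound 3 (0.16 log units; within the scatter) stays within the scatter, and the values of compound 3 and compound 2 also lie within the scatter of each other, so no order among the three can be read from these numbers. The only measured step, that from compound 1 to compound 3, concerns the drawing of a stereocentre alone, as shown by the fact that one of compounds 1 and 3 is drawn with a defined configuration and the other without, at the place where they differ; it changes no atom or bond.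

Compound 4, `c1ccc(COc2cccc(-c3cn(C4CN5CCC4CC5)nn3)c2)cc1`, is not yet measured. It differs from compound 3 by benzyloxy in place of fluoro on an aromatic carbon. Going by the values given here, no measured step concerns a change of this kind: the one step available is a stereo-drawing difference and says nothing about swapping a fluoro for a benzyloxy. The estimate for compound 4 therefore rests on the value of compound 3 alone and carries a wide range. In this assay compound 4 is expected to give roughly 1500 nM, somewhere between 300 nM and 8000 nM. This expected step a 2.0-fold higher number from compound 3 to compound 4 (0.30 log units; within the scatter) is not one that the present data can support or refute beyond the scatter.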

Compound 4, inhibition constant: 668 nM
Beside the measured number, compound 4's estimate is 2.2-fold (0.35 log units) above it; measured number inside the range.
By their numbers in this assay, from the lowest: compounds 2, 1, 4 and 3 (each within the scatter of the next).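

In this assay, going by these compounds alone, the exchange of fluoro for benzyloxy on an aromatic carbon, meta to a large group, gives a 1.1-fold lower number from compound 3 to compound 4 (0.05 log units; within the scatter) and is the first step that alters the substituent rather than the drawing of a stereocentre. At this place, a group of 8 heavy atoms carrying its own six-membered aromatic ring of carbon only thus stands where a single fluorine stood, and the two compounds cannot be told apart in this read-out. Within the data shown here, the only available evidence concerns a stereo-drawing difference and does not bear on this exchange of groups, so the result comes with no explanation.

As far as these compounds go, it remains open whether other groups at this same place, such as methoxy, an amine, a carboxylic acid or a chain longer than benzyloxy, would also stay within the scatter of compound 3 in this assay. Compound 4 is drawn without a configuration at the saturated ring carbon, so the values shown also leave open how its separate S and R forms would read.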